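Dropping a Fluoro from the Sulfonyl Aryl Ring

The source may hold more compounds than are shown below. What is called first, only, known or untested is meant among the compounds shown, and "the series" means these compounds.

Measured so far:
compound 1 `N#Cc1cccc(S(=O)(=O)c2cnc3c(F)cccc3c2-c2cccc(F)c2)c1` gives 0.34 mL/min
compound 2 `O=S(=O)(c1ccc(F)c(F)c1)c1cnc2c(F)cccc2c1-c1cccc(F)c1` gives 1.28 mL/min

In an ADME assay on microsomes from liver (Homo sapiens) for metabolic stability, tested at 2.5 uM (a lower number here means slower removal, a higher number faster removal of the compound), compound 2 stands highest of the two, with compound 1 nearest at a 3.8-fold higher number from compound 1 to compound 2 (0.58 log units; beyond the scatter). Compound 3 `O=S(=O)(c1cccc(F)c1)c1cnc2c(F)cccc2c1-c1cccc(F)c1` differs from compound 2 by hydrogen in place of fluoro on an aromatic carbon. Going by the values given here, no measured step swaps a single fluoro for hydrogen; the only step known, from compound 1 to compound 2, changes the whole aryl group and is a modest one. Compound 3 is therefore expected to sit close to compound 2, with a 1.3-fold lower number from compound 2 to compound 3 (0.11 log units; within the scatter) likely within the scatter, giving an estimate of 1 mL/min with a range from 0.4 mL/min to 2.5 mL/min.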

Compound 3, intrinsic clearance in a liver preparation (reported as CLH), per the amount of preparation that the assay uses: 1.14 mL/min
Compound 3: middle estimate off by 1.1-fold (0.06 log units), on the low side, and the stated range covers the measured number.
By their numbers in this assay, from the lowest: compound 1; then compounds 3 and 2 (each within the scatter of the next).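

In this assay, 3-fluorophenyl in place of 3,4-difluorophenyl gives a 1.1-fold lower number from compound 2 to compound 3 (0.05 log units; within the scatter), so removing this one fluoro makes no readable difference. Fluoro in place of cyano on the same ring gives a 3.4-fold higher number from compound 1 to compound 3 (0.53 log units; beyond the scatter), which shows that the earlier gap does not depend on the second fluoro and goes with replacing the nitrile. Nothing available explains why the nitrile compound gives the lower number. Going by these compounds, it remains open where an amine or a carboxylic acid in the nitrile's place would fall, and whether a second nitrile on the ring would change the number.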